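Tert-butyl on the Biaryl Series: a Second Look

A few compounds are considered here, and "the series" means these few. Any claim that something is new, unique, unknown or untested is made for them only; others in the source may bear on it.

Measured compounds:
Compound 1 `O=C1NC(=S)S/C1=C\c1ccccc1OCc1ccccc1` in a functional assay on A549 cells (Homo sapiens) for inhibition, read by sulforhodamine B assay (on this read-out higher numbers stand for weaker inhibition of growth and lower numbers for stronger inhibition of growth), gives 13000 nM.
Compound 2 `CC(C)(C)c1ccc(OCc2ccccc2)c(/C=C2\SC(=S)NC2=O)c1` in this assay gives 7000 nM.
Compound 3 `O=C1NC(=O)/C(=C/c2cc(-c3ccccc3)ccc2OCc2ccccc2)S1` in this assay gives 2000 nM.

Compounds 1 and 2 share a core, and compound 2 differs from compound 1 by tert-butyl in place of hydrogen on an aromatic carbon. The step they show is a 1.9-fold lower number from compound 1 to compound 2 (0.27 log units; within the scatter). Compound 3 differs from compound 1 in more than one place, and the difference between the two cores is not broken down here; what can be said is that compound 3 gives the lowest number of the three, with both steps toward it lying beyond the scatter.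

Compound 4 `CC(C)(C)c1ccc(-c2ccc(OCc3ccccc3)c(/C=C3\SC(=O)NC3=O)c2)cc1` has not yet been measured. It differs from compound 3 by tert-butyl in place of hydrogen on an aromatic carbon. This is the same kind of change as that from compound 1 to compound 2, but the surroundings of the place differ: in compound 2 the entering group sits meta to a group of 8 heavy atoms and para to a benzyloxy group, whereas in compound 4 it sits para to a large group on the outer ring.

Going by the values given here, the only measured precedent is the step from compound 1 to compound 2, which stayed within the scatter. On that basis the step of a 1.5-fold lower number from compound 3 to compound 4 (0.19 log units; within the scatter) is expected to be small as well, and compound 4 is estimated at 1300 nM in this assay, with a likely range from 500 nM to 4000 nM.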

Compound 4, concentration for 50% growth inhibition: 2000 nM
Compound 4: the middle estimate sits 1.5-fold (0.19 log units) below what was measured; measured number inside the range.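

In this assay, tert-butyl in place of hydrogen on an aromatic carbon gives no change at the digits printed from compound 3 to compound 4 (within the scatter), and set beside the earlier case, the two steps do not part: the same change on two cores in this assay, a 1.9-fold lower number (0.27 log units; within the scatter) from compound 1 to compound 2 and no change at the digits printed (within the scatter) from compound 3 to compound 4, 1.9-fold (0.27 log units) apart, within the scatter of two such steps. This shows that, in these two pairs, the change carries from the core of compound 1 to the core of compound 3 without a step beyond the scatter on either core, even though the entering group stands in different surroundings in compound 2 and compound 4. It does not show that tert-butyl is without effect throughout the series. Two pairs in a single assay are a narrow base, and they give no reason why the number stays within the scatter on both cores.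

The compounds shown leave open whether another group at the same place, such as an amine, a carboxylic acid or a longer chain, would move the number beyond the scatter on either core. They also leave open whether tert-butyl would give the same result at another place on these rings, and which of the several differences between the two cores bears on growth inhibition.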